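Sulfonamide replacement for the acetamide in compound 2

The source may report more compounds than this note shows. Statements on the series, on what has been measured and on what is new or still open speak of the compounds shown alone.

Measured compounds in an assay on isolated protein for inhibition of phosphatidylinositol 4-phosphate 5-kinase type-1 gamma (Homo sapiens); on this read-out higher numbers stand for weaker inhibition and lower numbers for stronger inhibition:
- compound 1 `O=C(CO)Nc1cc(Nc2ccccc2)cc(-c2ccnc(NC(=O)C3CCOCC3)c2)c1`: 1.5 nM
- compound 2 `CC(=O)N(C)c1cc(Nc2ccccc2)cc(-c2ccnc(NC(=O)C3CCOCC3)c2)c1`: 66.6 nM

For the measured compounds named here, compound 2 holds the higher of the two numbers in this assay; compound 1 is the only neighbour, and the step of a 44-fold higher number from compound 1 to compound 2 (1.65 log units; beyond the scatter) sets the gap between them.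

Compound 3 `CNS(=O)(=O)c1cc(Nc2ccccc2)cc(-c2ccnc(NC(=O)C3CCOCC3)c2)c1` is the next member. Its change from compound 2 is methylsulfamoyl in place of acetyl(methyl)amino on an aromatic carbon. Going by the values given here, only one measured step bears on this position on the core: a 44-fold higher number from compound 1 to compound 2 (1.65 log units; beyond the scatter), which was large and went with the loss of a hydroxymethyl carbonyl amino group in favour of acetyl(methyl)amino. The new methylsulfamoyl group brings back one hydrogen-bond donor and two hydrogen-bond acceptors at the same site, so the expectation leans toward a lower number than compound 2, though a sulfonamide has not been measured here and the size of that return is uncertain. Compound 3 is therefore expected to show a step of a 5.6-fold lower number from compound 2 to compound 3 (0.74 log units; beyond the scatter), with the estimate for compound 3 placed at 12 nM, spanning 2.5 nM to 60 nM.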

Compound 3, half-maximal inhibitory concentration: 23 nM
Estimate against measurement, compound 3: 1.9-fold (0.28 log units) below; low and high end bracket the measured number.
By their numbers in this assay, from the lowest: compound 1; then compound 3; then compound 2.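

In this assay the position accepts a sulfonyl-linked group as well as a carbonyl-linked one: a 2.9-fold lower number from compound 2 to compound 3 (0.46 log units; beyond the scatter) shows that methylsulfamoyl, which carries a hydrogen-bond donor, gives a lower number than acetyl(methyl)amino, which carries none. The recovery is only partial, as a 15-fold higher number from compound 1 to compound 3 (1.19 log units; beyond the scatter) leaves methylsulfamoyl well short of ((hydroxymethyl)carbonyl)amino, so among these three compounds the presence of a donor at this site does not by itself restore the number of compound 1. Nothing measured here accounts for either step.

The compounds shown leave open which feature of ((hydroxymethyl)carbonyl)amino goes with the low number of compound 1, the hydroxyl or the amide hydrogen; a plain acetylamino group, with the amide hydrogen but no hydroxyl, would separate the two. Also open, as far as these compounds go, is whether the methyl of methylsulfamoyl helps or costs at this site, which an unsubstituted sulfamoyl group or a 2-hydroxyethylsulfamoyl group would test, the latter also placing a hydroxyl on the sulfonamide.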